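This account rests on a few compounds, and the source may have more. Where it says the series, first, only, none or still open, it means among the compounds named here.

Compound 1, `COc1cc(OC)c2c(=O)c(OCC(=O)N/N=C/c3sccc3C)c(-c3cc(OC)c(OC)c(OC)c3)oc2c1`: 10300 nM
Compound 2, `COc1cc(OC)c2c(=O)c(OCC(=O)N/N=C/c3ccc(C)cc3)c(-c3cc(OC)c(OC)c(OC)c3)oc2c1`: 10100 nM
Compound 3, `COc1cc(OC)c2c(=O)c(OCCCCN3CCN(C)CC3)c(-c3cc(OC)c(OC)c(OC)c3)oc2c1`: 6950 nM

Of the compounds shown here, three built on the same core have been tested in a functional assay on SGC-7901 cells (Homo sapiens) for cytotoxicity, read by MTT assay, with a stated time of 38 h; on this read-out higher numbers stand for weaker inhibition and lower numbers for stronger inhibition. Compound 1 stands at the highest of the three numbers, though its separation from the others is slight: there is a 1.0-fold lower number from compound 1 to compound 2 (0.01 log units; within the scatter) and a 1.5-fold lower number from compound 1 to compound 3 (0.17 log units; within the scatter), each within the scatter. Compound 4, `CCN(CC)CCCOc1c(-c2cc(OC)c(OC)c(OC)c2)oc2cc(OC)cc(OC)c2c1=O`, has not yet been measured. It differs from compound 1 in one place: a group of 7 heavy atoms (6 carbon, 1 nitrogen; no ring) in place of a group of 11 heavy atoms (7 carbon, 2 nitrogen, 1 oxygen, 1 sulfur; one five-membered aromatic ring with 1 hetero atom), on a saturated chain carbon bound to an oxygen on an aromatic ring. The most relevant measured steps are those in which the same kind of hydrazone-bearing group is exchanged for a basic amine chain on the same saturated chain carbon. There the record shows a 1.5-fold lower number from compound 1 to compound 3 (0.17 log units; within the scatter) and a 1.5-fold lower number from compound 2 to compound 3 (0.16 log units; within the scatter), both small and both within the scatter. Among the compounds with values here, compound 4 carries a shorter chain and an amine without a ring, so the precedent is approximate rather than exact; still, nothing among the measured compounds points to a large shift in this assay. Compound 4 is therefore expected to show a 1.5-fold lower number from compound 1 to compound 4 (0.17 log units; within the scatter), a change that would not itself exceed the scatter. The estimate for compound 4 in this assay is 7000 nM, with a range from 3000 nM to 15000 nM.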

Compound 4, half-maximal inhibitory concentration: 56900 nM
Compound 4: middle estimate off by 8.1-fold (0.91 log units), on the low side; measured number above the stated range.
By their numbers in this assay, from the lowest: compounds 3, 2 and 1 (each within the scatter of the next); then compound 4.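

In this assay, within the data shown here, this place, a saturated chain carbon bound to an oxygen on an aromatic ring, turns out to be able to move the number beyond the scatter, which no exchange among the earlier compounds had done: 2-(diethylamino)ethyl gives a weaker result than either of the two groups with an aromatic ring that it replaces (a 5.5-fold higher number from compound 1 to compound 4 (0.74 log units; beyond the scatter); a 5.6-fold higher number from compound 2 to compound 4 (0.75 log units; beyond the scatter)). The largest step is the one between the two amine-bearing chains, with diethylamino in place of (4-methylpiperazin-1-yl)methyl (an 8.2-fold higher number from compound 3 to compound 4 (0.91 log units; beyond the scatter)), so an amine on this chain does not in itself hold the number at the level of the other compounds. Nothing at hand accounts for this rise.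

That last step changes the amine and the chain length together, so the compounds shown cannot say which of the two carries the loss. A 4-methylpiperazin-1-yl group on the shorter chain, or a diethylamino group on a longer chain, would separate them, and a pyrrolidin-1-yl amine would test how far the result extends to other amines.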